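Trifluoromethyl on compound 3: a flat series so far

The compounds below may be only part of what the source reports. "The series", "measured", "known", "first", "only" and "open" are said of these compounds alone.

In a functional assay on MDA-MB-436 cells (Homo sapiens) for antiproliferative activity, read by MTT assay, with a stated time of 24 h (a lower number here means a stronger inhibitor, a higher number a weaker inhibitor), compound 1 (`O=C(O)CC(NS(=O)(=O)c1ccc(C(F)(F)F)cc1)c1ccccc1`) gives 54700 nM, compound 2 (`O=C(O)CC(NS(=O)(=O)c1ccc(C(F)(F)F)cc1)c1ccccc1F`) gives 55600 nM and compound 3 (`O=C(O)CC(NS(=O)(=O)c1ccccc1)c1ccc(Cl)cc1Cl`) gives 59000 nM. Compound 3 lies within the scatter of both others, so the three hold no rank among themselves.

Compound 4 (`O=C(O)CC(NS(=O)(=O)c1ccc(C(F)(F)F)cc1)c1ccc(Cl)cc1Cl`) comes from compound 3 by a single change: trifluoromethyl in place of hydrogen on an aromatic carbon, para to a large group. Within the data shown here, no measured pair isolates this change. Among the measured compounds shown here, the only measured step, a 1.0-fold higher number from compound 1 to compound 2 (0.01 log units; within the scatter), is fluoro in place of hydrogen on an aromatic carbon, and it stays within the scatter.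

The nearest evidence is indirect. Compound 1 (54700 nM) and compound 2 (55600 nM) carry trifluoromethyl, while compound 3 (59000 nM) lacks it and still lies within the scatter of both. No shift beyond the scatter is therefore expected, and the estimated step is a 1.1-fold lower number from compound 3 to compound 4 (0.03 log units; within the scatter). The estimated value for compound 4 is 55000 nM, with an expected range of 30000 nM to 95000 nM.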

Compound 4, half-maximal inhibitory concentration: 37600 nM
Compound 4: the middle estimate sits 1.5-fold (0.17 log units) above what was measured; low and high end bracket the measured number.
By their numbers in this assay, from the lowest: compounds 4, 1, 2 and 3 (each within the scatter of the next).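

In this assay, among these compounds, compound 3 and compound 4 form the first pair that isolates trifluoromethyl in place of hydrogen on an aromatic carbon, para to a large group, and this step stays within the scatter (a 1.6-fold lower number from compound 3 to compound 4 (0.20 log units; within the scatter)). With trifluoromethyl held in place, 2,4-dichlorophenyl in place of 2-fluorophenyl (a 1.5-fold lower number from compound 2 to compound 4 (0.17 log units; within the scatter)) and 2,4-dichlorophenyl in place of phenyl (a 1.5-fold lower number from compound 1 to compound 4 (0.16 log units; within the scatter)) on the saturated chain carbon also stay within the scatter, so neither site has yet given a step beyond it among these four compounds. No independent evidence bears on these small steps.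

As far as these compounds go, whether an amine or a nitrile at the trifluoromethyl position would give a step beyond the scatter remains open. So does the outcome of a primary amide in place of the carboxylic acid shared by all four compounds.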